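A few compounds are considered here, and "the series" means these few. Any claim that something is new, unique, unknown or untested is made for them only; others in the source may bear on it.

Three compounds have been measured in a functional assay on HUVEC cells (Homo sapiens) for inhibition, tested at 5 ug/mL; on this read-out lower numbers stand for a weaker effect and higher numbers for a stronger effect at the one concentration tested:
compound 1 `COc1cc(/C=C/C(=O)c2cccc(NC(=O)c3cccs3)c2)ccc1O`, 80%
compound 2 `COc1cc(/C=C/C(=O)c2cccc(NC(=O)c3cc(Cl)cc(Cl)c3)c2)ccc1O`, 51%
compound 3 `CCOC(=O)C(=O)Nc1cccc(C(=O)/C=C/c2ccc(O)c(OC)c2)c1`, 45%

Among these three numbers compound 2 stands second highest. Its nearest neighbour is compound 3, whose number sits so close that repeat measurement could not tell the two apart. Its furthest neighbour is compound 1, which lies clearly higher.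

Compound 4 `COc1cc(/C=C/C(=O)c2cccc(NC(C)=O)c2)ccc1O` has not yet been tested. It differs from compound 2 in one place only: methyl in place of 3,5-dichlorophenyl on a carbonyl carbon.

All three measured steps change the group on this same carbonyl carbon. Starting from thiophen-2-yl, a number 29 percentage points lower from compound 1 to compound 2 (beyond the scatter) and a number 35 percentage points lower from compound 1 to compound 3 (beyond the scatter); both alternatives gave a weaker effect than compound 1. Between the two alternatives themselves, a number 6 percentage points lower from compound 2 to compound 3 (within the scatter), so swapping 3,5-dichlorophenyl for the smaller ethoxycarbonyl made no difference that could be trusted. For the measured compounds named here, no measured step involves methyl, so the expectation rests on this comparison alone.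

A small step downward, or none beyond the scatter, is therefore expected for a number 6 percentage points lower from compound 2 to compound 4 (within the scatter). Compound 4 is estimated to give 45% in this assay. For compound 4 the expected range runs from 25% to 65%.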

Compound 4, a percentage reported as inhibition, at one concentration (the size of the read-out at that concentration, not a potency): 15%
Beside the measured number, compound 4's estimate is 30 percentage points above it; the whole stated range lies above it.
By their numbers in this assay, from the lowest: compound 4; then compounds 3 and 2 (each within the scatter of the next); then compound 1.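

In this assay, methyl on this carbonyl carbon gives a far weaker effect than any other group shown: a number 36 percentage points lower from compound 2 to compound 4 (beyond the scatter), a number 30 percentage points lower from compound 3 to compound 4 (beyond the scatter) and a number 65 percentage points lower from compound 1 to compound 4 (beyond the scatter). The earlier compounds shown here showed only that thiophen-2-yl stood above the two alternatives, whereas compound 4 shows that the effect can fall much further through a change at this one place, and that the ring in the leaving group is not the whole story, since the ethoxycarbonyl group of compound 3 carries no ring yet stays clearly above methyl. Nothing available here explains why methyl gives so much less than the other groups.

On these data alone, it remains open whether a longer chain such as ethyl or propyl, or an amine, on this carbonyl carbon would stay close to compound 4 or rise to the level of compound 3. As far as these compounds go, all four numbers also come from a single concentration, so they show only a stronger or weaker effect at that concentration, and how the compounds would compare at other concentrations is still unknown.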